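The compounds below may be only part of what the source reports. "The series", "measured", "known", "first", "only" and "open" are said of these compounds alone.

Working notes on the series.

Compound 1 `Cc1ccc(S(=O)(=O)NCc2ccc(CNC(=O)c3cccc(Cl)c3)cc2)cc1` gives 100 nM in an assay on MDA-MB-231 cells for binding affinity to C-X-C chemokine receptor type 4 (Homo sapiens), read by immunofluorescence and microscopy, with stated times of 10 min and 30 min; on this read-out lower numbers stand for an effect already at smaller amounts and higher numbers for an effect only at larger amounts of compound. Compound 2 `Cc1ccc(S(=O)(=O)NCc2ccc(CNC(=O)c3cccc(C)c3)cc2)cc1` gives 1000 nM in this assay. Compound 3 `Cc1cccc(C(=O)NCc2ccc(CNS(=O)(=O)c3ccccc3)cc2)c1` gives 1000 nM in this assay.

Compound 2 and compound 1 share one core and differ in a single place: chloro in place of methyl on an aromatic carbon. This change gives a 10-fold lower number from compound 2 to compound 1 (1.00 log units; beyond the scatter). Compound 2 and compound 3 differ in the core itself, by hydrogen in place of methyl on an aromatic carbon; that change gives no change at the digits printed from compound 2 to compound 3 (within the scatter), so compound 2 and compound 3 stand level at the digits recorded, together the highest two numbers of the three.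

Compound 4 `O=C(NCc1ccc(CNS(=O)(=O)c2ccccc2)cc1)c1cccc(Cl)c1` is not yet measured. It stands to compound 3 as compound 1 stands to compound 2: chloro in place of methyl on an aromatic carbon. The place line for this change reads the same word for word as for the change from compound 2 to compound 1, so it is the same change carried onto the core of compound 3. Going by the values given here, the only guide for its size is the one measured instance, which gave a 10-fold lower number from compound 2 to compound 1 (1.00 log units; beyond the scatter); the two cores otherwise differ only by the change just named, and that change gave no shift between compound 2 and compound 3.

Compound 4 is therefore expected to show a step of a 10-fold lower number from compound 3 to compound 4 (1.00 log units; beyond the scatter) from compound 3, estimated on the strength of a 10-fold lower number from compound 2 to compound 1 (1.00 log units; beyond the scatter). Compound 4 is expected to give about 100 nM in this assay, with a likely range from 30 nM to 400 nM. Whether the step carries over at the same size rests on a single pair and must be confirmed by the measurement.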

Compound 4, effective concentration (reported as EC, without a stated level of effect): 1000 nM
Compound 4: middle estimate off by 10-fold (1.00 log units), on the low side; the whole stated range lies below it.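

Chloro in place of methyl gives no change at the digits printed from compound 3 to compound 4 (within the scatter), so the step seen on the core of compound 2 does not carry over to the core of compound 3 in this assay: the same change on two cores in this assay, a 10-fold lower number (1.00 log units; beyond the scatter) from compound 2 to compound 1 and no change at the digits printed (within the scatter) from compound 3 to compound 4, 10-fold (1.00 log units) apart, beyond the scatter of two such steps. Hydrogen in place of methyl gives a 10-fold higher number from compound 1 to compound 4 (1.00 log units; beyond the scatter), although the same change left compound 2 and compound 3 level, so in these four compounds the effect of a change in one place depends on what stands in the other: the same change on two cores in this assay, no change at the digits printed (within the scatter) from compound 2 to compound 3 and a 10-fold higher number (1.00 log units; beyond the scatter) from compound 1 to compound 4, 10-fold (1.00 log units) apart, beyond the scatter of two such steps. Going by these compounds alone, both comparisons hang on compound 1, the one value that stands apart at 100 nM, so they show that the two changes do not simply add up here, but not why, nor whether this holds beyond these four compounds.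

The compounds shown leave open whether another group in the place of the chloro, such as bromo, fluoro or methoxy, also depends on the methyl in the other place. From the compounds shown here alone, it also remains open whether a group other than methyl in that other place, such as chloro or methoxy, would give the same result as the methyl of compound 1.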